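The source may report more compounds than this note shows. Statements on the series, on what has been measured and on what is new or still open speak of the compounds shown alone.

Measured compounds in a functional assay on HepG2 cells (Homo sapiens) for cytotoxicity, read by MTT assay, with a stated time of 48 h; a higher number here means a weaker inhibitor, a lower number a stronger inhibitor:
Compound 1, `Cc1ccccc1-c1nnc(SCCn2c([N+](=O)[O-])cnc2C)o1`: 5100 nM
Compound 2, `COc1cc(OC)cc(-c2nnc(SCCn3c([N+](=O)[O-])cnc3C)o2)c1`: 10500 nM

Among the measured compounds shown here, of the two compounds measured so far in this assay, compound 1 gives the lower number, and the number for compound 2 stands higher by a margin beyond the usual scatter of repeated measurements. Compound 1 thus stands as the stronger inhibitor of the pair, with compound 2 the weaker one.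

Compound 3, `Cc1ncc([N+](=O)[O-])n1CCSc1nnc(-c2cnccc2N)o1`, has not yet been measured in this assay. It differs from compound 1 in a single place: 4-aminopyridin-3-yl in place of 2-methylphenyl on an aromatic carbon. For the measured compounds named here, no step between measured compounds matches this change, so the size of its effect is not known from the data at hand. The change from compound 1 to compound 3 is expected to shift the number little, with a small rise toward a weaker inhibitor as the more likely direction, a step described by a 1.4-fold higher number from compound 1 to compound 3 (0.14 log units; within the scatter). Compound 3 is therefore estimated to give about 7000 nM in this assay, within a range from 2500 nM to 20000 nM.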

Compound 3, half-maximal inhibitory concentration: 8400 nM
For compound 3 the middle estimate is 1.2-fold (0.08 log units) below the measured one; measured number inside the range.
By their numbers in this assay, from the lowest: compounds 1, 3 and 2 (each within the scatter of the next, the first and the last beyond it).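

In this assay the position on the aromatic carbon of the five-membered ring now has its first readable step: putting 4-aminopyridin-3-yl in place of 2-methylphenyl gives a 1.6-fold higher number from compound 1 to compound 3 (0.22 log units; within the scatter) and so leaves the two compounds indistinguishable. The swap exchanges a ring of carbon only, with no hydrogen-bond donors or acceptors, for a ring with a hetero atom that carries both, and the number stays within the scatter. No measurement at hand accounts for this result.

From the compounds shown here alone, how a plain phenyl, a pyridin-3-yl without the amine, or a carboxylic acid on this ring would read remains open, so the separate contributions of the ring nitrogen and the amine cannot be told apart. Going by these compounds, a longer chain between the sulfur and the nitroimidazole-bearing end also remains untested here.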